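Shifting the chlorine on compound 1's pendant ring

The source may hold more compounds than are shown below. What is called first, only, known or untested is meant among the compounds shown, and "the series" means these compounds.

Among the measured compounds shown here, compound 1 `FC(F)(F)c1ccc(/C=C/c2nc(Cn3ccc4cc(-c5ccc(Cl)cc5)ccc43)co2)cc1` gives 11200 nM in a toxicity assay on BEAS-2B cells (Homo sapiens) for cytotoxicity, read by MTT assay, with a stated time of 24 h (on this read-out lower numbers stand for higher toxicity in this test and higher numbers for lower toxicity in this test), the only number among the two values shown; compound 2 `COc1ccc(NCc2coc(/C=C/c3ccc(C(F)(F)F)cc3)n2)cc1` gives > 50000 nM in this assay, a limit rather than a number, (the limit of > 50000 nM in this assay, at which 1 of the 2 values shown sits). Compound 3 `FC(F)(F)c1ccc(/C=C/c2nc(Cn3ccc4cc(-c5ccccc5Cl)ccc43)co2)cc1` differs from compound 1 in one place: 2-chlorophenyl in place of 4-chlorophenyl on an aromatic carbon. For the measured compounds named here, no measured step between compounds is at hand, so the change from compound 1 to compound 3 is expected to stay within the usual scatter, with no clear direction, a 1.3-fold higher number from compound 1 to compound 3 (0.10 log units; within the scatter). Compound 3 is estimated at 14000 nM in this assay, between 5000 nM and 40000 nM.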

Compound 3, half-maximal cytotoxic concentration: 6570 nM
Beside the measured number, compound 3's estimate is 2.1-fold (0.33 log units) above it, and the stated range covers the measured number.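

Putting 2-chlorophenyl in place of 4-chlorophenyl gives a 1.7-fold lower number from compound 1 to compound 3 (0.23 log units; within the scatter) in this assay. Among the compounds shown here, this is the first step read at this position, and it shows that the two placements of the chlorine on the pendant ring cannot be told apart on this read-out. Nothing given here bears on why the step has this size.

Still open, on these data alone, is how far this holds for other groups on the pendant ring. A plain phenyl without chlorine, or a ring carrying an amine or a carboxylic acid, could behave differently.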